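The source may report more compounds than this note shows. Statements on the series, on what has been measured and on what is new or still open speak of the compounds shown alone.

Compound 1, `Cc1ccc(/N=N/N(C)C(=O)CCc2ccc(O)cc2)cc1`, and compound 3, `CN(/N=N/c1ccc(Br)cc1)C(=O)CCc1ccc(O)cc1`, share one core and differ in a single place: bromo in place of methyl on an aromatic carbon. In a physicochemical assay for pharmacokinetics, read by HPLC, in phosphate buffer, at pH 7.4 (a lower number here means that the compound disappears faster, a higher number that the compound lasts longer), compound 1 gives 101 h. In this assay compound 3 gives 106 h, and the change made a 1.0-fold higher number from compound 1 to compound 3 (0.02 log units; within the scatter). Compound 2, `Cc1ccc(/N=N/N(C)C(=O)NCCSc2ccc(O)cc2)cc1`, is built on another core; how that core differs from the core of compound 1 is not broken down here. In this assay compound 2 reaches only a limit of the assay, > 240 h, and not a number. Compound 4, `CN(/N=N/c1ccc(Br)cc1)C(=O)NCCSc1ccc(O)cc1`, is not yet measured in this assay. It differs from compound 2 by the same change that separates compound 1 from compound 3: bromo in place of methyl on an aromatic carbon. Since that change gave a 1.0-fold higher number from compound 1 to compound 3 (0.02 log units; within the scatter), the step expected from compound 2 to compound 4 in this assay is a step that the limit leaves unreadable from compound 2 to compound 4, with the starting point already at the limit of > 240 h in this assay, at which 1 of the 3 values shown sits. Compound 4 is therefore expected to last about 300 h, most likely between 150 h and 600 h, and quite possibly to be reported again only as a limit.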

Compound 4, half-life: > 240 h
Compound 4: only a limit was reported (the forecaster's own chance of this, stated with the estimate: 70%); the middle value does not contradict the limit.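

No new step can be read from compound 2 to compound 4 in this assay, because each of the two compounds is reported only as a limit and not as a number: the limit of > 240 h in this assay, at which 2 of the 4 values shown sit.

The compounds shown leave open whether bromo in place of methyl on an aromatic carbon changes the half-life on the core of compound 2.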